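The compounds below may be only part of what the source reports. "The series", "measured", "known", "first", "only" and "open" are said of these compounds alone.

Compound 1, `COc1cccc(N2CCN(C(=O)C(C)N3C(=O)CCC3=O)CC2)c1`, is one of three close analogues that share a core and differ only in the aryl group carried on the amine nitrogen in a ring. In a functional assay on the whole organism (strain Swiss) with Mus musculus as the target, in the maximal electroshock model, with a stated time of 1 h, at a dose of 300 mg/kg by the intraperitoneal route (a higher number here means a stronger effect of the compound at the dose given, a lower number a weaker effect), compound 1 gives 0%. Compound 2, `CC(C(=O)N1CCN(c2ccc(Cl)cc2)CC1)N1C(=O)CCC1=O`, gives 0%, and compound 3, `CC(C(=O)N1CCN(c2ccc(F)cc2)CC1)N1C(=O)CCC1=O`, gives 25%. Compound 1 therefore stands level with compound 2 at the bottom of the three numbers, while compound 3 stands apart from both.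

Compound 4, `CC(C(=O)N1CCN(c2cccc(C(F)(F)F)c2)CC1)N1C(=O)CCC1=O`, is not yet measured. It departs from compound 1 in one place: trifluoromethyl in place of methoxy on an aromatic carbon. Two steps describe what exchanging the aryl substituent has done so far. no change at the digits printed from compound 1 to compound 2 (within the scatter), whereas a number 25 percentage points higher from compound 1 to compound 3 (beyond the scatter); between those two, a number 25 percentage points higher from compound 2 to compound 3 (beyond the scatter). Among the compounds with values here, none of the measured steps introduces trifluoromethyl, and none alters a substituent meta to a large group, so they bear on the step to compound 4 only loosely, showing that a change of this kind can leave the number unmoved or lift it modestly, but nothing larger.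

Compound 4 is accordingly expected to give 10% in this assay, within a range from 0% to 40%, which would mean a step of a number 10 percentage points higher from compound 1 to compound 4 (within the scatter) that is estimated to be small, at most modest.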

Compound 4, a percentage reported as activity, at one dose (the size of the read-out at that dose, not a potency): 100%
Compound 4: middle estimate off by 90 percentage points, on the low side, outside the stated range (above it).
By their numbers in this assay, from the lowest: compounds 1 and 2 (each within the scatter of the next); then compound 3; then compound 4.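

In this assay, the exchange of methoxy for trifluoromethyl on an aromatic carbon, meta to a large group, gives a number 100 percentage points higher from compound 1 to compound 4 (beyond the scatter). Within the data shown here, the earlier steps between aryl groups left the number unmoved or lifted it modestly, so this is the first sign that a single substituent exchange on this aromatic ring can produce a large change in the read-out. The exchange swaps a group of 2 heavy atoms with 1 hydrogen-bond acceptor for one of 4 heavy atoms with 0 hydrogen-bond acceptors, but nothing available bears on why the step is so large.

The compounds shown leave open whether the gain belongs to trifluoromethyl itself or would follow from other replacements of methoxy at this place, a question that a methyl, a chloro or a nitrile group there could help to settle. As far as these compounds go, the read-out is also the size of the effect at one dose, so how potent the compounds are remains open.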